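Aryl ester variation on the shared core: compound 4

This account rests on a few compounds, and the source may have more. Where it says the series, first, only, none or still open, it means among the compounds named here.

The shared core carries an ester whose aryl group is varied. Compound 1 `COc1cc(C2Oc3cc([C@H]4Oc5cc(O)cc(O)c5C(=O)[C@@H]4O)ccc3OC2COC(=O)c2cc([N+](=O)[O-])cc([N+](=O)[O-])c2)ccc1O` gives 14600 nM in a functional assay on liver (Rattus norvegicus, strain Sprague-Dawley) for inhibition, with a stated time of 1 h; on this read-out lower numbers stand for stronger inhibition and higher numbers for weaker inhibition. Compound 2 `COc1cc(C2Oc3cc([C@H]4Oc5cc(O)cc(O)c5C(=O)[C@@H]4O)ccc3OC2COC(=O)c2cc(OC)c(OC)c(OC)c2)ccc1O` gives 25700 nM in this assay, and compound 3 `COc1cc(C2Oc3cc([C@H]4Oc5cc(O)cc(O)c5C(=O)[C@@H]4O)ccc3OC2COC(=O)c2ccc(N)cc2)ccc1O` gives 14300 nM. Compound 3 shows the lowest of the three numbers, yet both of its steps to the others lie within the scatter: a 1.0-fold lower number from compound 1 to compound 3 (0.01 log units; within the scatter) and a 1.8-fold lower number from compound 2 to compound 3 (0.25 log units; within the scatter). Compound 4 `COc1cc(C2Oc3cc([C@H]4Oc5cc(O)cc(O)c5C(=O)[C@@H]4O)ccc3OC2COC(=O)c2cc(N)cc([N+](=O)[O-])c2)ccc1O` differs from compound 3 by 3-amino-5-nitrophenyl in place of 4-aminophenyl on a carbonyl carbon. The step of a 1.0-fold lower number from compound 1 to compound 3 (0.01 log units; within the scatter) bears most on it: compound 4 holds an amino group and a nitro group within one aryl ring. No aryl change here moved the number beyond the scatter, so for compound 4 none is expected: a 1.0-fold higher number from compound 3 to compound 4 (0.01 log units; within the scatter). Compound 4 is therefore estimated at 14500 nM, range 7000 nM to 30000 nM.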

Compound 4, half-maximal inhibitory concentration: 200 nM
For compound 4 the middle estimate is 73-fold (1.86 log units) above the measured one; measured number below the stated range.
By their numbers in this assay, from the lowest: compound 4; then compounds 3, 1 and 2 (each within the scatter of the next).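

In this assay this ester position is not flat: 3-amino-5-nitrophenyl stands apart from 4-aminophenyl (a 72-fold lower number from compound 3 to compound 4 (1.85 log units; beyond the scatter)) and from 3,4,5-trimethoxyphenyl (a 130-fold lower number from compound 2 to compound 4 (2.11 log units; beyond the scatter)). Amino in place of nitro on an aromatic carbon also gives a large step (a 73-fold lower number from compound 1 to compound 4 (1.86 log units; beyond the scatter)), so among the compounds shown, only the aryl ring holding both amino and nitro moves the number beyond the scatter. No measurement at hand accounts for this step.

Still open, as far as these compounds go, is whether a nitrile or a carboxylic acid in place of the nitro group keeps the low number. Also open, from the compounds shown here alone, is whether 3,5-diaminophenyl does the same.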